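A few compounds are considered here, and "the series" means these few. Any claim that something is new, unique, unknown or untested is made for them only; others in the source may bear on it.

Measured compounds:
- compound 1 `CCCC(=O)Nc1cccc(NC(=O)COc2ccc3c(=O)ccoc3c2)c1`: 176 nM
- compound 2 `O=C(COc1ccc2c(=O)ccoc2c1)Nc1cccc(NC(=O)c2cccc([N+](=O)[O-])c2)c1`: 41 nM

Both compounds were tested in an assay on isolated protein for inhibition of Rho-associated protein kinase 2 (Homo sapiens), read by scintillation counting, radiometric assay and 33P incorporation, with a stated time of 40 min, in the presence of a further agent that is not named here; on this read-out lower numbers stand for stronger inhibition and higher numbers for weaker inhibition. Among the compounds with values here, of the two numbers known, compound 2 has the lowest, and its only neighbour is compound 1, which stands a 4.3-fold lower number from compound 1 to compound 2 (0.63 log units; beyond the scatter) away. That one step, a 4.3-fold lower number from compound 1 to compound 2 (0.63 log units; beyond the scatter), is the whole record for the carbonyl carbon in question, and it shows that what sits there matters to the read-out.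

Compound 3 `O=C(COc1ccc2c(=O)ccoc2c1)Nc1cccc(NC(=O)c2ccc(C(=O)O)cc2)c1` is the next compound to be measured in this assay. It differs from compound 2 at that same carbonyl carbon: 4-carboxyphenyl in place of 3-nitrophenyl on a carbonyl carbon. Within the data shown here, the one measured step bears on this position but not on this exchange, since it swapped a propyl for an aromatic ring rather than one substituted ring for another. With no comparison between two such rings available, the expected step of a 1.5-fold higher number from compound 2 to compound 3 (0.17 log units; within the scatter) is taken to be none beyond the scatter, with a wide margin either way. For compound 3 in this assay the estimate is 60 nM, within a range from 20 nM to 200 nM.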

Compound 3, half-maximal inhibitory concentration: 2030 nM
The estimate for compound 3 lay 34-fold (1.53 log units) below the measured number, and the stated range ends below it.
By their numbers in this assay, from the lowest: compound 2; then compound 1; then compound 3.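

In this assay, this carbonyl carbon tolerates some aromatic rings far better than others: the exchange of 3-nitrophenyl for 4-carboxyphenyl gives a 50-fold higher number from compound 2 to compound 3 (1.69 log units; beyond the scatter), even though both groups contain one six-membered aromatic ring of carbon only and the same number of heavy atoms. Having a ring at this place therefore does not by itself give a lower number, as the 4-carboxyphenyl group also falls behind the simple propyl chain, with a 12-fold higher number from compound 1 to compound 3 (1.06 log units; beyond the scatter), so what the ring carries, or where it carries it, matters greatly. Nothing measured here explains why the number rises so sharply.

The exchange alters two things at once, the group on the ring and its place, as the names 3-nitrophenyl and 4-carboxyphenyl show, so these three compounds cannot tell which of the two drives the step. A 3-carboxyphenyl or a 4-nitrophenyl group on the same carbonyl carbon would separate the two, and the methyl ester of the carboxylic acid would show whether the free acid itself is tied to the higher number.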